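The source may hold more compounds than are shown below. What is called first, only, known or untested is meant among the compounds shown, and "the series" means these compounds.

Two related compounds have been tested so far in a functional assay on A549 cells (Homo sapiens) for cytotoxicity; on this read-out higher numbers stand for weaker inhibition and lower numbers for stronger inhibition. Compound 1 `C=C/C=C\[C@H](C)[C@H](OC(N)=O)[C@@H](C)[C@H](O)[C@@H](C)C/C(C)=C\[C@H](C)[C@@H](O)[C@@H](C)/C=C\[C@@H](O)C[C@@H]1OC(=O)[C@H](C)[C@@H](O[Si](C)(C)C(C)(C)C)[C@H]1C` gives 1990 nM in this test, while compound 2 `C=C/C=C\[C@H](C)[C@H](OC(N)=O)[C@@H](C)[C@H](O)[C@@H](C)C[C@@](C)(O)[C@H]1[C@H](C)[C@@H](O)[C@@H](C)[C@@H]1/C=C/C[C@@H]1OC(=O)[C@H](C)[C@@H](O)[C@H]1C` gives 840 nM and so holds the lower number of the pair. That means stronger inhibition, and the gap between the two lies beyond the usual scatter. Compound 3 `C=C/C=C\[C@H](C)[C@H](OC(N)=O)[C@@H](C)[C@H](O)[C@@H](C)C[C@](C)(O)[C@H]1[C@H](C)[C@@H](O)[C@@H](C)[C@@H]1/C=C/C[C@@H]1OC(=O)[C@H](C)[C@@H](O)[C@H]1C` has not been measured yet. Set against compound 2, its structure shows this change: the two compounds have the same atoms and bonds and differ only in configuration as drawn: 1 of 17 stereo elements differ; a stereocentre at a saturated chain carbon is drawn R in compound 2 and S in compound 3. Going by the values given here, no measured pair shows what such a switch alone does, so the direction is uncertain. A modest rise in the number is expected, with wide margins, and the estimated change is a 1.8-fold higher number from compound 2 to compound 3 (0.25 log units; within the scatter). For compound 3 the expected value is 1500 nM, with an estimated range from 450 nM to 5000 nM.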

Compound 3, half-maximal inhibitory concentration: 2640 nM
Compound 3: middle estimate off by 1.8-fold (0.25 log units), on the low side, and the stated range covers the measured number.
By their numbers in this assay, from the lowest: compound 2; then compounds 1 and 3 (each within the scatter of the next).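

In this assay, switching this saturated chain carbon from R to S gives a 3.1-fold higher number from compound 2 to compound 3 (0.50 log units; beyond the scatter), so a change at this single stereocentre moves the read-out by more than the usual scatter. Going by these compounds alone, no earlier pair had isolated such a switch, and this one gives it a direction: the R form, compound 2, holds the lower number, which means stronger inhibition. The step can be assigned to this one centre because no atom or bond changes between the two compounds: the fact that compounds 2 and 3 differ only in the configuration as drawn

Going by these compounds, only two configurations at one carbon are compared here, so it remains open whether the other stereo elements matter as much as this one. Also open, on these data alone, is what an amine or a methyl ether at this carbon would do to the number.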